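Swapping chloro for methoxy on a second core

A few compounds are considered here, and "the series" means these few. Any claim that something is new, unique, unknown or untested is made for them only; others in the source may bear on it.

Compound 1, `CC(O[N+](=O)[O-])C(=O)Nc1ccc(C(=O)/C=C/c2ccc(Cl)cc2)cc1`, is measured in a functional assay on the whole organism (strain albino) for inhibition, with Rattus norvegicus as the target, read by paw edema, with stated times of 30 min and 3 h, at a dose of 100 mg/kg by the oral route (a lower number here means less inhibition, a higher number more inhibition at the dose given (going by the name of the read-out)), and gives 62%. Compound 2, `COc1ccc(/C=C/C(=O)c2ccc(NC(=O)C(C)O[N+](=O)[O-])cc2)cc1`, carries methoxy in place of chloro on an aromatic carbon and in this assay gives 50%. This change produced a number 12 percentage points lower from compound 1 to compound 2 (beyond the scatter).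

Compound 3, `C/C(=N/O)c1ccc(OCC(=O)Nc2ccc(C(=O)/C=C/c3ccc(Cl)cc3)cc2)cc1`, is built on a different core; the difference between the two cores is not broken down here. In this assay compound 3 gives 66%, a number close to that of compound 1 and further from that of compound 2.

Compound 4, `COc1ccc(/C=C/C(=O)c2ccc(NC(=O)COc3ccc(/C(C)=N\O)cc3)cc2)cc1`, has not been measured. It differs from compound 3 by methoxy in place of chloro on an aromatic carbon, the same change that separates compound 2 from compound 1, sitting on an aromatic carbon of a six-membered aromatic ring of carbon only, para to a large group, in both pairs. The step from compound 3 to compound 4 is therefore expected to resemble the earlier one: a number 12 percentage points lower from compound 3 to compound 4 (beyond the scatter) is the estimated size, resting on the step from compound 1 to compound 2. On that basis compound 4 is expected to give about 54%, most likely between 44% and 64%.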

Compound 4, a percentage reported as inhibition, in the whole organism at one dose (the size of the read-out at that dose, not a potency): 46%
Beside the measured number, compound 4's estimate is 8 percentage points above it; the range from low to high includes it.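

In this assay, methoxy in place of chloro again gives a lower number on the second core, with a number 20 percentage points lower from compound 3 to compound 4 (beyond the scatter). The two steps can be read as one effect of similar size on both cores: the same change on two cores in this assay, a number 12 percentage points lower (beyond the scatter) from compound 1 to compound 2 and a number 20 percentage points lower (beyond the scatter) from compound 3 to compound 4, 8 percentage points apart, within the scatter of two such steps. Within the data shown here, this supports carrying the change between these two cores, but it rests on only two pairs of compounds, so it does not show that the change would act alike on any other core, and it does not explain why the number falls.

The compounds shown leave open how a fluoro group or an amine on the same aromatic carbon would compare with chloro and methoxy, and whether a longer chain such as ethoxy would behave like methoxy. Since each number is the size of the effect at a single dose, they also leave open whether the step would keep its size at other doses.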